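The source may report more compounds than this note shows. Statements on the series, on what has been measured and on what is new or still open speak of the compounds shown alone.

Of the compounds shown here, two built on a shared core have been measured in a functional assay on Hs-578T cells (Homo sapiens) for inhibition, read by sulforhodamine B assay, with a stated time of 48 h; on this read-out higher numbers stand for weaker inhibition of growth and lower numbers for stronger inhibition of growth. Compound 1 `O=C(Nc1ccccc1OC(F)(F)F)Nc1n[nH]c2ccccc12` gives 19400 nM. Compound 2 `Nc1nn(C(=O)Nc2ccc(Cc3ccccc3)cc2)c2ccccc12` gives 17200 nM, the lowest of the two numbers shown, yet the gap to compound 1 lies within the usual scatter of repeated measurements, so the two cannot be ranked against each other. Compound 3 `CCCCOc1ccc(NC(=O)n2nc(N)c3ccccc32)cc1` has not yet been measured. It differs from compound 2 in one place: butoxy in place of benzyl on an aromatic carbon, para to a large group. For the measured compounds named here, no measured pair in this set shows the effect of such a change, so there is no step to lean on, and the single comparison available, between compound 1 and compound 2, shows two compounds with high numbers sitting at nearly the same level. On that basis the step from compound 2 to compound 3 is expected to be small, as a 1.2-fold higher number from compound 2 to compound 3 (0.07 log units; within the scatter), with no direction that can be trusted beyond the scatter. Compound 3 is therefore estimated at 20000 nM, most likely between 6000 nM and 60000 nM.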

Compound 3, concentration for 50% growth inhibition: 20200 nM
Compound 3: the middle estimate sits 1.0-fold (0.00 log units) below what was measured, and the stated range covers the measured number.
By their numbers in this assay, from the lowest: compounds 2, 1 and 3 (each within the scatter of the next).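

In this assay, butoxy in place of benzyl on an aromatic carbon, para to a large group, gives a 1.2-fold higher number from compound 2 to compound 3 (0.07 log units; within the scatter), so the two groups cannot be told apart by this read-out. For the compounds shown here, this is the first direct look at this position: the swap removes a six-membered aromatic ring of carbon only and brings in an open chain with no ring and a hydrogen-bond acceptor, yet the number stays within the scatter and remains high, which means weak inhibition of growth. No measurement at hand explains why two such different groups read alike.

As far as these compounds go, both groups tried here are fairly large, so it remains open whether something quite different at this position, such as an amine, a carboxylic acid or a single methoxy group, would shift the number beyond the scatter. From the compounds shown here alone, it also remains open whether a longer chain than butoxy, or a butoxy group moved to another carbon of the same ring, would bring the number down from this high level.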